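This account rests on a few compounds, and the source may have more. Where it says the series, first, only, none or still open, it means among the compounds named here.

Measured in a functional assay on MDA-MB-436 cells (Homo sapiens) for antiproliferative activity, read by MTT assay, with a stated time of 48 h; a higher number here means a weaker inhibitor, a lower number a stronger inhibitor:
Compound 1 `CCCNC(=O)N1CCN(c2ncnc3sc(-c4ccc(N5CCN(C)CC5)cc4)cc23)CC1` gives 12400 nM
Compound 2 `CN1CCN(c2ccc(-c3cc4c(N5CCN(C(=O)Nc6ccc(OC(F)(F)F)cc6)CC5)ncnc4s3)cc2)CC1` gives 6250 nM
Compound 3 `CN1CCN(c2ccc(-c3cc4c(N5CCN(C(=O)Nc6ccccc6F)CC5)ncnc4s3)cc2)CC1` gives 14300 nM

Compound 3 cannot be told apart from compound 1 (a 1.2-fold higher number from compound 1 to compound 3 (0.06 log units; within the scatter)) and stands only modestly above compound 2 (a 2.3-fold higher number from compound 2 to compound 3 (0.36 log units; beyond the scatter)). Compound 4 `CC(C)c1cccc(C(C)C)c1NC(=O)N1CCN(c2ncnc3sc(-c4ccc(N5CCN(C)CC5)cc4)cc23)CC1` keeps the shared core and has 2,6-diisopropylphenyl in place of 2-fluorophenyl on an amide-type nitrogen.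

All three measured steps fall at this same place, and all are small. The remaining one also stays within the scatter (a 2.0-fold lower number from compound 1 to compound 2 (0.30 log units; within the scatter)). Among the compounds with values here, no measured compound carries 2,6-diisopropylphenyl, so these steps are only a loose guide. No step beyond the scatter is expected in this assay, with a slight lean toward a lower number, as compound 2 (6250 nM) shows that another aryl group here can stand lower than compound 3 does. The expected change is small (a 1.4-fold lower number from compound 3 to compound 4 (0.16 log units; within the scatter)). Compound 4 is expected at 10000 nM within an estimated range (4000 nM to 25000 nM).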

Compound 4, half-maximal inhibitory concentration: 11300 nM
Compound 4: middle estimate off by 1.1-fold (0.05 log units), on the low side; low and high end bracket the measured number.
By their numbers in this assay, from the lowest: compounds 2, 4, 1 and 3 (each within the scatter of the next, the first and the last beyond it).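

In this assay, 2,6-diisopropylphenyl, with 12 heavy atoms, replaces 2-fluorophenyl, with 7, on the amide-type nitrogen without a step beyond the scatter (a 1.3-fold lower number from compound 3 to compound 4 (0.10 log units; within the scatter)). Within the data shown here, compound 4 also stays within the scatter of the other two compounds (a 1.8-fold higher number from compound 2 to compound 4 (0.26 log units; within the scatter); a 1.1-fold lower number from compound 1 to compound 4 (0.04 log units; within the scatter)), so the only gap beyond the scatter at this position remains the one between compound 2 and compound 3. Nothing available accounts for this result or for that one gap.

On these data alone, it remains open whether a group of another kind on this nitrogen, such as a longer alkyl chain, a primary amine or a carboxylic acid on the phenyl ring, would produce a step beyond the scatter. The compounds shown also leave open how any change outside this position would read in this assay.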